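Exposure series: ethers at the aryl oxygen

The source may hold more compounds than are shown below. What is called first, only, known or untested is meant among the compounds shown, and "the series" means these compounds.

Measured compounds:
compound 1 `CCOC(=O)c1c(-c2cccc(OC)c2)[nH]c2cc(OC)ccc2c1=O`: 5800 nM
compound 2 `CCOC(=O)c1c(-c2cccc(OCC)c2)[nH]c2cc(OC)ccc2c1=O`: 2400 nM

In an in vivo ADME assay on the whole organism (strain CD1) for pharmacokinetics, with Mus musculus as the target, at a dose of 200 mg/kg by the oral route (on this read-out higher numbers stand for higher exposure at the dose given and lower numbers for lower exposure), compound 1 gives 5800 nM and compound 2 gives 2400 nM, the lower of the two numbers. Going by the values given here, the single measured step, a 2.4-fold lower number from compound 1 to compound 2 (0.38 log units; beyond the scatter), is the only one that touches the same oxygen on an aromatic ring. Compound 3 `CCOC(=O)c1c(-c2cccc(Oc3ccccc3)c2)[nH]c2cc(OC)ccc2c1=O` carries phenyl in place of ethyl on an oxygen on an aromatic ring. Growth at that oxygen lowered the number once, so a further modest drop is expected, a 2.0-fold lower number from compound 2 to compound 3 (0.30 log units; within the scatter), with wide uncertainty. Compound 3 is estimated at 1200 nM, range 400 nM to 3500 nM.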

Compound 3, maximal plasma concentration: 400 nM
The estimate for compound 3 lay 3.0-fold (0.48 log units) above the measured number, and the stated range covers the measured number.
By their numbers in this assay, from the lowest: compound 3; then compound 2; then compound 1.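

Ethoxy to phenoxy on the oxygen on an aromatic ring brings a 6.0-fold lower number from compound 2 to compound 3 (0.78 log units; beyond the scatter) in this assay and methoxy to phenoxy brings a 15-fold lower number from compound 1 to compound 3 (1.16 log units; beyond the scatter) as the only large step at this oxygen. Among these three ethers, the number falls from methyl through ethyl to phenyl, and no compound here goes against that order. No measured evidence bears on the reason for the fall.

Open, on these data alone, is whether a longer chain such as propyl follows the same order at this oxygen. A cyclohexyl or benzyl group would show whether the drop is specific to phenyl.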